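The source may report more compounds than this note shows. Statements on the series, on what has been measured and on what is new or still open speak of the compounds shown alone.

Of the compounds shown here, three share a lactone core and have been tested in an ADME assay on RAW264.7 cells (Mus musculus) for cytotoxicity, read by MTT assay, with a stated time of 24 h, in the absence of a further agent; on this read-out higher numbers stand for weaker inhibition and lower numbers for stronger inhibition. Compound 1, `O=C1OC(Cc2nc(-c3ccc(Oc4ccccc4)cc3)no2)c2ccccc21`, sits at a limit of the assay in this assay, where compound 1 gives > 40000 nM. Compound 2, `COCCCOc1ccc(C(O)C2OC(=O)c3c(OC)cc(OC)cc32)cc1`, also rests at a limit, and in this assay compound 2 gives > 40000 nM. Compound 3, `CCOCCOc1ccc(C(O)C2OC(=O)c3c(OC)cc(OC)cc32)cc1`, likewise gives only a limit in this assay, where compound 3 gives > 40000 nM. For the measured compounds named here, the single step between measured compounds that differ in one place, a step that the two limits leave unreadable from compound 2 to compound 3, cannot be read because the limit of > 40000 nM in this assay, at which 3 of the 3 values shown sit, covers both ends of it, so compound 3 stands at the same limit as the other two rather than at a number.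

The step now followed leads from compound 3 to compound 4, `COc1cc(OC)c2c(c1)C(C(O)c1ccc(OCc3ccc(OC(F)F)cc3)cc1)OC2=O`, through (4-(difluoromethoxy)phenyl in place of ethoxymethyl on a saturated chain carbon bound to an oxygen on an aromatic ring). Going by the values given here, the change replaces a short chain with a ring bearing two fluorines, and no measured step bears on it, since the only available step is unreadable. Among the compounds with values here, with every value so far at the limit, no movement beyond the scatter in this assay is expected, and the step that the limit leaves unreadable from compound 3 to compound 4 is estimated to leave compound 4 at the limit as well. In this assay compound 4 is therefore expected to give about 45000 nM, with a range from 20000 nM to 100000 nM.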

Compound 4, half-maximal inhibitory concentration: > 40000 nM
Compound 4: only a limit was reported; the forecaster's own chance of this, stated with the estimate: 80%; the middle value does not contradict the limit.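

Neither new step, from compound 3 to compound 4 or from compound 2 to compound 4, can be read, because compound 4 also gives only a limit in this assay: the limit of > 40000 nM in this assay, at which 4 of the 4 values shown sit.

The compounds shown leave open how any of the four truly compares with another in this assay.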